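Adding a fluorine to the central ring of compound 1

The source may hold more compounds than are shown below. What is called first, only, known or untested is meant among the compounds shown, and "the series" means these compounds.

Compound 1 `Cc1cc(=O)n(-c2cccc(F)c2)nc1C(=O)Nc1ccc(Oc2ncnc3ccsc23)cc1` is the starting point here. In a functional assay on HepG2 cells (Homo sapiens) for cytotoxicity, read by MTT assay, with a stated time of 72 h (a higher number here means a weaker inhibitor, a lower number a stronger inhibitor), compound 1 gives 10200 nM, the second highest of three numbers. Compound 2 `Cc1cc(=O)n(-c2ccc(F)cc2)nc1C(=O)Nc1ccc(Oc2ncnc3ccsc23)cc1` gives 2110 nM in this assay, and the step of a 4.8-fold lower number from compound 1 to compound 2 (0.68 log units; beyond the scatter) is a swap of the group on the aromatic nitrogen. Compound 3 `Cc1ccc(-n2nc(C(=O)Nc3ccc(Oc4ncnc5ccsc45)cc3)c(C)cc2=O)c(C)c1` gives 17900 nM, with the step of a 1.8-fold higher number from compound 1 to compound 3 (0.24 log units; within the scatter) and, from compound 2, an 8.5-fold higher number from compound 2 to compound 3 (0.93 log units; beyond the scatter).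

Compound 4 `Cc1cc(=O)n(-c2cccc(F)c2)nc1C(=O)Nc1ccc(Oc2ncnc3ccsc23)c(F)c1` differs from compound 1 elsewhere: fluoro in place of hydrogen on an aromatic carbon, the ring being the six-membered aromatic ring of carbon only that carries the amide nitrogen and the ether oxygen, ortho to a large group and meta to a large group. All three measured steps concern only the group on the aromatic nitrogen, so none of them bears on this change, and there is no measured guide to its effect.

Among the compounds with values here, with no comparable step available, the expected step of a 1.3-fold lower number from compound 1 to compound 4 (0.11 log units; within the scatter) is one within the scatter, in no clear direction. Compound 4 is therefore estimated at 8000 nM in this assay, with a range from 2500 nM to 25000 nM.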

Compound 4, half-maximal inhibitory concentration: 7810 nM
Compound 4: middle estimate off by 1.0-fold (0.01 log units), on the high side; the measured number falls inside the stated range.
By their numbers in this assay, from the lowest: compound 2; then compounds 4, 1 and 3 (each within the scatter of the next, the first and the last beyond it).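

Fluoro in place of hydrogen on this aromatic carbon, ortho to a large group and meta to a large group, is the first change shown away from the group on the aromatic nitrogen, and in this assay it gives a 1.3-fold lower number from compound 1 to compound 4 (0.12 log units; within the scatter) and so leaves the two numbers indistinguishable. A swap on the aromatic nitrogen can count for more, as with a 4.8-fold lower number from compound 1 to compound 2 (0.68 log units; beyond the scatter) and its size beyond the scatter, whereas this single fluoro has no measurable effect on the number here. Nothing measured here offers an explanation for this result.

On these data alone, it remains open whether a chloro, a methoxy or an amine on this same carbon would also leave the number in place. As far as these compounds go, it is also open whether the same fluoro would behave this way when added to compound 2 rather than compound 1.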